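The source may report more compounds than this note shows. Statements on the series, on what has been measured and on what is new or still open speak of the compounds shown alone.

Of the compounds shown here, three that share a core have been measured in a functional assay on HCT-116 cells (Homo sapiens) for inhibition, with a stated time of 72 h; a lower number here means a stronger inhibitor, a higher number a weaker inhibitor. Compound 1, `NC1CCC(Nc2nc(NCc3ccc(-c4ccccc4)cc3)c3ncn(C4CCCC4)c3n2)CC1`, gives 745 nM, which places it in the middle of the three. Compound 3, `NC1CCC(Nc2nc(NCc3ccc(-c4cccc(F)c4)nc3)c3ncn(C4CCCC4)c3n2)CC1`, gives 74 nM, a lower number and so a stronger inhibitor. Compound 2, `CC(C)(O)CNc1nc(NCc2ccc(-c3ccco3)cc2)c2ncn(C3CCCC3)c2n1`, gives 16700 nM, a higher number and so a weaker one. Both gaps from compound 1 lie beyond the usual scatter of repeated measurements.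

Compound 4, `NC1CCC(Nc2nc(NCc3cc(Cl)ccc3O)c3ncn(C4CCCC4)c3n2)CC1`, has not yet been measured. It differs from compound 1 in one place, with 5-chloro-2-hydroxyphenyl in place of 4-phenylphenyl on a saturated chain carbon bound to a nitrogen on an aromatic ring. Among the compounds with values here, no measured compound carries 5-chloro-2-hydroxyphenyl, so the evidence for this change is indirect. Compound 3 reaches 74 nM with a second aromatic ring on this group, and compound 4 loses that second ring. Compound 2 also holds a second ring and still gives 16700 nM, so this link is loose.

A moderate move towards weaker inhibition, just beyond the scatter, is expected in this assay. The expected step is a 2.7-fold higher number from compound 1 to compound 4 (0.43 log units; beyond the scatter). For compound 4 the estimated value is 2000 nM, within a range of 400 nM to 10000 nM.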

Compound 4, half-maximal inhibitory concentration: 350 nM
Beside the measured number, compound 4's estimate is 5.7-fold (0.76 log units) above it; the whole stated range lies above it.
By their numbers in this assay, from the lowest: compound 3; then compound 4; then compound 1; then compound 2.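

Replacing 4-phenylphenyl with 5-chloro-2-hydroxyphenyl on a saturated chain carbon bound to a nitrogen on an aromatic ring gives a 2.1-fold lower number from compound 1 to compound 4 (0.33 log units; beyond the scatter) in this assay, so this position does not need a second aromatic ring for the inhibition seen here: a single ring does modestly better. The change alters several things at once, removing one aromatic ring while adding a chlorine and a hydroxyl with its hydrogen-bond donor and acceptor, so this single step cannot assign the shift to any one of those parts. Nothing available explains why the number moves in this direction.

The compounds shown leave open whether the chlorine, the hydroxyl or the loss of the second ring accounts for the step, which a plain phenyl, a 2-hydroxyphenyl without chlorine or a 3-chlorophenyl without hydroxyl at this position would help to separate. On these data alone, it also remains open whether a methoxy in place of the hydroxyl would give a similar number.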